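Nitro-to-methyl swap on the anilide of compound 1

The source may hold more compounds than are shown below. What is called first, only, known or untested is meant among the compounds shown, and "the series" means these compounds.

Compound 1 `O=C(/C=C/C(=O)N1C/C(=C\c2ccc([N+](=O)[O-])cc2)C(=O)/C(=C/c2ccc([N+](=O)[O-])cc2)C1)Nc1ccc([N+](=O)[O-])cc1` carries a nitro group on each of its three aromatic rings. In a functional assay on CCRF-CEM cells (Homo sapiens) for cytotoxicity (on this read-out lower numbers stand for stronger inhibition and higher numbers for weaker inhibition), compound 1 gives 410 nM, the lower of the two numbers recorded so far. Compound 2 `CC(=O)c1ccc(NC(=O)/C=C/C(=O)N2C/C(=C\c3ccccc3)C(=O)/C(=C/c3ccccc3)C2)cc1`, which has an acetyl group on the anilide ring and unsubstituted benzylidene rings, gives in this assay 1700 nM; the gap to compound 1 lies beyond the scatter. Among the compounds with values here, compound 2 differs from compound 1 in more than one place, so no single-change step is available from the measured pair.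

Within the data shown here, compound 3 `Cc1ccc(NC(=O)/C=C/C(=O)N2C/C(=C\c3ccc([N+](=O)[O-])cc3)C(=O)/C(=C/c3ccc([N+](=O)[O-])cc3)C2)cc1` is the first single-point variant: methyl in place of nitro on an aromatic carbon while both benzylidene nitro groups remain. Among the measured compounds shown here, no measured step isolates this change. For the measured compounds named here, the only pointer is that the one compound without a nitro on the anilide ring, compound 2 at 1700 nM, sits above compound 1, though other changes are mixed into that comparison. For compound 3 a modest weakening beyond the scatter is expected, the step from compound 1 to compound 3 estimated at a 2.2-fold higher number from compound 1 to compound 3 (0.34 log units; beyond the scatter). Compound 3 is thus estimated at 900 nM, with a range from 350 nM to 2500 nM.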

Compound 3, half-maximal inhibitory concentration: 890 nM
The estimate for compound 3 lay 1.0-fold (0.00 log units) above the measured number, within the range that was stated.
By their numbers in this assay, from the lowest: compound 1; then compounds 3 and 2 (each within the scatter of the next).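

Within the data shown here, with both benzylidene nitro groups held fixed, methyl in place of nitro on the anilide ring, para to a large group, gives in this assay a 2.2-fold higher number from compound 1 to compound 3 (0.34 log units; beyond the scatter), the first reading of this position on its own. The step is modest and compound 3 still gives a clear number, so in this pair the nitro group on the anilide ring can be exchanged for methyl at a modest cost, even though the change takes away 3 heavy atoms and 2 hydrogen-bond acceptors and puts back 1 heavy atom and no acceptor. Nothing on hand explains the step, which therefore stands as an observation without a stated cause.

The compounds shown leave open whether the size of this step would hold on a core with unsubstituted benzylidene rings, and what each benzylidene nitro group contributes as a single change. They also leave open how an amine, a carboxylic acid or a methoxy group at the same place on the anilide ring would stand against nitro and methyl.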